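The source may hold more compounds than are shown below. What is called first, only, known or untested is meant among the compounds shown, and "the series" means these compounds.

Compound 1, with the structure `CC(C)N(Cc1cccc(OCCCCCC(=O)O)c1)C(=O)c1ccc(-c2ccncc2)cc1`, is the starting point. In an ADME assay on Raji cells (Homo sapiens) for cytotoxicity, read by CellTiter-Glo and resazurin assay, with a stated time of 72 h (on this read-out higher numbers stand for an effect only at larger amounts of compound and lower numbers for an effect already at smaller amounts), compound 1 gives only a limit, > 26000 nM, and not a number. Two measured relatives differ from it in one place. Compound 2, `CC(C)Oc1cccc(-c2ccc(C(=O)N(Cc3cccc(OCCCCCC(=O)O)c3)C(C)C)cc2)c1`, carries 3-isopropoxyphenyl in place of pyridin-4-yl on an aromatic carbon. In this assay compound 2 also gives only a limit, > 26000 nM. Compound 3, `CC(C)N(Cc1cccc(OCCCCCC(=O)O)c1)C(=O)c1ccc(-c2cccc(C(F)(F)F)c2)cc1`, carries 3-(trifluoromethyl)phenyl in place of pyridin-4-yl on an aromatic carbon. In this assay compound 3 gives a limit as well, > 26000 nM. Because every value sits at the limit of > 26000 nM in this assay, at which 3 of the 3 values shown sit, the three steps among these compounds cannot be read: a step that the two limits leave unreadable from compound 1 to compound 2, a step that the two limits leave unreadable from compound 1 to compound 3, and a step that the two limits leave unreadable from compound 2 to compound 3. Compound 4 is the unmeasured compound, `CC(C)N(Cc1cccc(OCCCCCC(=O)O)c1)C(=O)c1ccc(-c2ccc(Cl)c(Cl)c2)cc1`. Its difference from compound 1 is 3,4-dichlorophenyl in place of pyridin-4-yl on an aromatic carbon. The two measured changes at this same aromatic carbon, to 3-isopropoxyphenyl and to 3-(trifluoromethyl)phenyl, left the read-out at the limit, so no size or direction of step can be drawn from them for this assay, and the expectation is that compound 4 will also sit at or near the limit. The estimated step from compound 1 to compound 4 is therefore a step that the limit leaves unreadable from compound 1 to compound 4. Compound 4 is expected to give about 30000 nM, within a range from 14000 nM to 65000 nM.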

Compound 4, half-maximal effective concentration: > 26000 nM
Compound 4 gave a limit, no number; the forecaster's own chance of this, stated with the estimate: 75%; the middle value does not contradict the limit.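

Among the compounds shown here, compound 4 gives only a limit in this assay, not a number, and so do compound 1, compound 2 and compound 3, so no step from any of them to compound 4 can be read: the limit of > 26000 nM in this assay, at which 4 of the 4 values shown sit.

The compounds shown leave open whether any group at this aromatic carbon would give a measurable effect in this assay, and how large that effect would be.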